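Removing the amino group from an isoquinoline amide

The source may hold more compounds than are shown below. What is called first, only, known or untested is meant among the compounds shown, and "the series" means these compounds.

Measured so far:
Compound 1, `CCOc1cc([C@@H](Nc2ccc3cnccc3c2)C(=O)NS(=O)(=O)c2ccccc2)ccc1OC(C)C`, gives > 5000 nM in an assay on isolated protein for inhibition of Trypsin (Homo sapiens); a higher number here means a weaker inhibitor, a lower number a stronger inhibitor; this is a limit of the assay, not a number.
Compound 2, `CCOc1cc([C@@H](Nc2ccc3c(N)nccc3c2)C(=O)NS(=O)(=O)c2cccc(S(N)(=O)=O)c2)ccc1OC(C)C`, gives > 5000 nM in this assay, again a limit.
Compound 3, `CCOc1cc(C(Nc2ccc3c(N)nccc3c2)C(=O)NS(=O)(=O)c2cccc(S(N)(=O)=O)c2)ccc1OC(C)C`, gives > 5000 nM in this assay, also a limit.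

Compound 2 therefore stands only on a limit, and the same holds for every other value shown, as the limit of > 5000 nM in this assay, at which 3 of the 3 values shown sit, states. Going by the values given here, the one step that can be read between measured compounds, a step that the two limits leave unreadable from compound 2 to compound 3, is unreadable because the fact that one of compounds 2 and 3 is drawn with a defined configuration and the other without, at the place where they differ and because the limit of > 5000 nM in this assay, at which 3 of the 3 values shown sit, leave no numbers to compare.

Compound 4, `CCOc1cc([C@@H](Nc2ccc3cnccc3c2)C(=O)NS(=O)(=O)c2cccc(S(N)(=O)=O)c2)ccc1OC(C)C`, differs from compound 2 by hydrogen in place of amino on an aromatic carbon. Among the compounds with values here, no measured step bears on this change with a readable size, since every value sits at the limit. The expectation for compound 4 is therefore that this assay again reports only a limit, with a step that the limit leaves unreadable from compound 2 to compound 4 as an estimated step that cannot be read against the scatter. For compound 4 the estimate is 10000 nM, with a range from 5000 nM to 50000 nM.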

Compound 4, inhibition constant: > 5000 nM
Compound 4 gave a limit, no number; the forecaster's own chance of this, stated with the estimate: 90%; the middle value does not contradict the limit.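

Neither the step from compound 2 to compound 4 nor the step from compound 1 to compound 4 can be read, because both ends of each step are limits, not numbers: the limit of > 5000 nM in this assay, at which 4 of the 4 values shown sit. The compounds shown leave open whether swapping amino for hydrogen, or hydrogen for sulfamoyl, changes inhibition in this assay at all.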